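The source may hold more compounds than are shown below. What is called first, only, known or untested is meant among the compounds shown, and "the series" means these compounds.

In a functional assay on MDA-MB-468 cells (Homo sapiens) for antiproliferative activity, read by MTT assay, with a stated time of 48 h (a higher number here means a weaker inhibitor, a lower number a stronger inhibitor), compound 1 `COc1cccc(C(=O)Nc2cc3cnc(NCCN(C)C)cc3n(C)c2=O)c1` gives 17400 nM and compound 2 `CN(C)CCNc1cc2c(cn1)cc(NC(=O)/C=C/c1ccccc1)c(=O)n2C` gives 12100 nM. With only these two numbers to compare, compound 2 stands level with compound 1, and neither can be called the better inhibitor. Compound 3 `CC(=O)Nc1cc2cnc(NCCN(C)C)cc2n(C)c1=O` has not yet been measured. Among the measured compounds shown here, it keeps the shared core, and the only change from compound 2 is at the amide: methyl in place of 2-phenylethenyl on a carbonyl carbon. Put simply, this is methyl in place of 2-phenylethenyl on a carbonyl carbon.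

For the measured compounds named here, the one measured step at this carbonyl carbon is a 1.4-fold lower number from compound 1 to compound 2 (0.16 log units; within the scatter). A ring-bearing group stood on both sides of that swap, whereas here the ring leaves and only methyl enters, so that step is a weak guide. It shows no large effect from that swap, but it does not show what losing the ring does. A modest rise in the number is therefore expected, though a result within the scatter would be no surprise. The expected change is a 2.1-fold higher number from compound 2 to compound 3 (0.32 log units; beyond the scatter). Compound 3 is estimated at 25000 nM, with an expected range of 10000 nM to 70000 nM.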

Compound 3, half-maximal inhibitory concentration: > 100000 nM
Compound 3 was reported as a limit (the forecaster's own chance of this, stated with the estimate: 15%); middle value at least 4.0-fold (0.60 log units) away from the limit.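

Against the earlier compounds, this result adds one thing: the carbonyl carbon is not indifferent to what it carries. The step from compound 1 to compound 2 swapped one ring-bearing group for another, but with methyl in place of 2-phenylethenyl the result is an at least 8.2-fold higher number from compound 2 to compound 3 (0.91 log units; beyond the scatter), and with methyl in place of 3-methoxyphenyl it is an at least 5.7-fold higher number from compound 1 to compound 3 (0.75 log units; beyond the scatter). Across these three compounds, both ring-bearing groups go with lower numbers than methyl, and the value of compound 3 in this assay is a limit rather than a number, so these steps give only the smallest possible size of the loss: the limit of > 100000 nM in this assay, at which 1 of the 3 values shown sits.

As far as these compounds go, what remains open is whether the ring itself matters or simply the size of the group, since the step to methyl removes both together; a longer chain such as butyl, or a saturated ring such as cyclohexyl, would help to separate the two. It is also unclear whether a ring-bearing group at this place can do better than compound 2, for instance a phenyl ring carrying an amine or a carboxylic acid.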